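This account rests on a few compounds, and the source may have more. Where it says the series, first, only, none or still open, it means among the compounds named here.

Measured so far:
- compound 1, `O=C(/C=C/c1ccc2c(c1)B(O)OC2)c1ccc(Cl)cc1`, 7900 nM
- compound 2, `O=C(/C=C/c1ccc2c(c1)B(O)OC2)c1ccc(Cl)c(Cl)c1`, 3400 nM

Both were tested in a functional assay on MDA-MB-231 cells (Homo sapiens) for cytotoxicity, read by MTT assay, with a stated time of 48 h; a lower number here means a stronger inhibitor, a higher number a weaker inhibitor. Going by the values given here, compound 1 gives the higher of the two numbers; the only neighbour is compound 2, reached by a 2.3-fold lower number from compound 1 to compound 2 (0.37 log units; beyond the scatter), a modest step that comes from a chloro in place of hydrogen on an aromatic carbon.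

Compound 3, `O=C(/C=C/c1ccc2c(c1)B(O)OC2)c1ccccc1O`, has not been tested. It differs from compound 1 by 2-hydroxyphenyl in place of 4-chlorophenyl on a carbonyl carbon. Among the compounds with values here, no measured pair shows this kind of swap; the one known step concerns adding a chloro, not exchanging the whole ring substituent, so it bears on the question only loosely. With the chlorine gone and a hydroxyl in its place, the guess must be cautious. Compound 3 is expected to land close to compound 1 or somewhat weaker, the step of a 1.3-fold higher number from compound 1 to compound 3 (0.10 log units; within the scatter) being the estimate. For compound 3 the expected value is 10000 nM, with a range from 4000 nM to 25000 nM.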

Compound 3, half-maximal inhibitory concentration: 16900 nM
The estimate for compound 3 lay 1.7-fold (0.23 log units) below the measured number, within the range that was stated.
By their numbers in this assay, from the lowest: compound 2; then compound 1; then compound 3.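

Exchanging the ring on the carbonyl carbon matters in this assay: moving from 4-chlorophenyl to 2-hydroxyphenyl gives a 2.1-fold higher number from compound 1 to compound 3 (0.33 log units; beyond the scatter). So this site responds to replacing the whole ring substituent, and not only to adding a chloro as the earlier pair showed. The swap removes the chlorine, brings in a hydroxyl with its hydrogen-bond donor and acceptor, and alters the number in the group's name all at once, and no measurement available accounts for the weaker result.

These compounds cannot show which of those changes drives the step. On these data alone, it also remains open how an unsubstituted phenyl, a 4-hydroxyphenyl, or a ring carrying a methoxy group or an amine would compare on the same carbonyl carbon.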